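Cyano in Place of Dimethylamino: Expecting Compound 4

The source may report more compounds than this note shows. Statements on the series, on what has been measured and on what is new or still open speak of the compounds shown alone.

Three compounds have been measured in a functional assay on MCF-10A cells (Homo sapiens) for antiproliferative activity, with a stated time of 48 h; on this read-out lower numbers stand for an effect already at smaller amounts and higher numbers for an effect only at larger amounts of compound:
compound 1 `COc1ccc2nc(C)cc(NCc3ccccc3)c2c1` gives 25900 nM;
compound 2 `COc1cccc(CNc2cc(C)nc3ccc(OC)cc23)c1` gives 9700 nM;
compound 3 `COc1ccc2nc(C)cc(NCc3cccc(N(C)C)c3)c2c1` gives 14000 nM.

Compound 3 stands second highest of the three numbers, yet its gaps to compound 2 and to compound 1 both lie within the scatter, so no order among them can be claimed. Compound 4 `COc1ccc2nc(C)cc(NCc3cccc(C#N)c3)c2c1` differs from compound 3 by cyano in place of dimethylamino on an aromatic carbon, on an aromatic carbon of a six-membered aromatic ring of carbon only, meta to a large group. Among the compounds with values here, no measured step involves cyano. The steps touching the same carbon are a 1.9-fold lower number from compound 1 to compound 3 (0.27 log units; within the scatter) and a 1.4-fold higher number from compound 2 to compound 3 (0.16 log units; within the scatter), both small, while a 2.7-fold lower number from compound 1 to compound 2 (0.43 log units; beyond the scatter). Exchanging one small group for another at this carbon has so far moved the number little, so compound 4 is expected to show a 1.1-fold lower number from compound 3 to compound 4 (0.03 log units; within the scatter), nothing beyond the scatter. In this assay compound 4 is estimated at 13000 nM, within a range from 6000 nM to 30000 nM.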

Compound 4, half-maximal effective concentration: 13400 nM
For compound 4 the middle estimate is 1.0-fold (0.01 log units) below the measured one, within the range that was stated.
By their numbers in this assay, from the lowest: compounds 2, 4, 3 and 1 (each within the scatter of the next, the first and the last beyond it).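

In this assay, cyano on this aromatic carbon cannot be told apart from dimethylamino (a 1.0-fold lower number from compound 3 to compound 4 (0.02 log units; within the scatter)) or from methoxy (a 1.4-fold higher number from compound 2 to compound 4 (0.14 log units; within the scatter)). Within the data shown here, measured against hydrogen (a 1.9-fold lower number from compound 1 to compound 4 (0.29 log units; within the scatter)), cyano also stays inside the scatter, so methoxy remains the only group here whose step from hydrogen goes beyond it (a 2.7-fold lower number from compound 1 to compound 2 (0.43 log units; beyond the scatter)). Nothing available explains why these groups read alike. As far as these compounds go, whether a carboxylic acid, a primary amine or a longer chain on this carbon would read the same remains open.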